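Replacing thiophen-3-yl with 4-hydroxyphenyl: what to expect

This account rests on a few compounds, and the source may have more. Where it says the series, first, only, none or still open, it means among the compounds named here.

Compound 3 `COc1ccc(C(=O)/C=C/c2ccsc2)c2c1C=CC(C)(C)O2` is recorded in a functional assay on HT-29 cells (Homo sapiens) for antiproliferative activity, read by MTT assay, with a stated time of 24 h (on this read-out lower numbers stand for stronger inhibition and higher numbers for weaker inhibition), only as a limit of the assay, > 10000 nM, and not as a number; it is one of the values at that limit (the limit of > 10000 nM in this assay, at which 1 of the 3 values shown sits). Compound 4 `COc1ccc(C(=O)/C=C/c2ccc(O)cc2)c2c1C=CC(C)(C)O2` differs from it in a single place: 4-hydroxyphenyl in place of thiophen-3-yl on a double-bonded chain carbon bound to a double-bonded chain carbon. Among the compounds with values here, no measured step covers this exact exchange. Within the data shown here, the only measured step, a 15-fold higher number from compound 1 to compound 2 (1.18 log units; beyond the scatter), compares compound 1 `CCN(CC)c1ccc(/C=C/C(=O)c2ccc(OC)c3c2OC(C)(C)C=C3)cc1`, which gives 550 nM, with compound 2 `COc1ccc(C(=O)/C=C/c2ccc(N3CCCC3)cc2)c2c1C=CC(C)(C)O2`, which gives 8360 nM; it shows that altering the group on the double-bonded chain carbon can shift the result well beyond the scatter. Because compound 3 is known only as a limit, the step of an at least 1.1-fold lower number from compound 3 to compound 4 (0.04 log units; that floor lies within the scatter) is an expectation rather than a comparison. Compound 4 is estimated at 9000 nM, with a range from 2500 nM to 30000 nM, and a fair chance that this assay again reports only a limit.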

Compound 4, half-maximal inhibitory concentration: > 10000 nM
Compound 4 ended at the assay's limit (the forecaster's own chance of this, stated with the estimate: 45%); middle value at least 1.1-fold (0.04 log units) from the limit.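

Compound 4 is recorded only as a limit, not as a number, as compound 3 is: the limit of > 10000 nM in this assay, at which 2 of the 4 values shown sit.

The step between compound 3 and compound 4 cannot be read, so these two groups cannot be ranked. Hydroxy in place of diethylamino gives an at least 18-fold higher number from compound 1 to compound 4 (1.25 log units; beyond the scatter), whereas hydroxy in place of pyrrolidin-1-yl gives an at least 1.1-fold higher number from compound 2 to compound 4 (0.07 log units; that floor lies within the scatter), so hydroxy does not match the result of diethylamino on this aromatic carbon.

Open, as far as these compounds go, is how other amines on the same aromatic carbon, such as dimethylamino or piperidin-1-yl, would compare with diethylamino.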